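Pyridin-3-yl for phenyl on the alkyne

This account rests on a few compounds, and the source may have more. Where it says the series, first, only, none or still open, it means among the compounds named here.

Of the compounds shown here, two that share one core have been measured in a functional assay on HEK293 cells for positive allosteric modulation of metabotropic glutamate receptor 5 (Homo sapiens), read by FLIPR and calcium flux; a higher number here means that more compound is needed for the effect, a lower number that less compound is needed. Compound 1 `O=C1c2ccc(C#Cc3ccccc3)nc2CCN1C1CCCC1` gives 5.9 nM. Compound 2 `O=C1c2ccc(C#Cc3ccccc3)nc2CCN1C1CCCCC1` gives 40 nM. Within the data shown here, the one measured step between them, a 6.8-fold higher number from compound 1 to compound 2 (0.83 log units; beyond the scatter), changes the ring on the amide-type nitrogen and nothing else. On the numbers shown, compound 2 stands highest of the two, with compound 1 the nearest and lower.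

Compound 3 `O=C1c2ccc(C#Cc3cccnc3)nc2CCN1C1CCCCC1` has not been measured. It differs from compound 2 on a triple-bonded carbon: pyridin-3-yl in place of phenyl on a triple-bonded carbon. Among the measured compounds shown here, no measured step touches this part of the molecule; the only step known, a 6.8-fold higher number from compound 1 to compound 2 (0.83 log units; beyond the scatter), sits on the amide-type nitrogen and so offers no direct guide to a change on the alkyne. With no matching comparison at hand, the expectation is a step of a 1.5-fold higher number from compound 2 to compound 3 (0.18 log units; within the scatter) in this assay, which is to say no shift clearly beyond the scatter in either direction. Compound 3 is therefore estimated at 60 nM in this assay, within a range from 15 nM to 250 nM.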

Compound 3, half-maximal effective concentration: 387 nM
For compound 3 the middle estimate is 6.5-fold (0.81 log units) below the measured one, and the stated range ends below it.
By their numbers in this assay, from the lowest: compound 1; then compound 2; then compound 3.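

The group on the triple-bonded carbon is not a neutral spot in this series: replacing phenyl with pyridin-3-yl, a ring of the same size with one carbon exchanged for nitrogen and one hydrogen-bond acceptor gained, gives a 9.7-fold higher number from compound 2 to compound 3 (0.99 log units; beyond the scatter) in this assay. The earlier compounds shown here showed sensitivity only at the ring on the amide-type nitrogen, whereas both measured steps now lie beyond the scatter, so the number responds to changes in two separate parts of the molecule. Nothing measured here accounts for the effect of this exchange, so its cause remains unknown.

From the compounds shown here alone, it remains open whether the result belongs to pyridin-3-yl alone or would also appear with pyridin-2-yl, pyridin-4-yl or a fluorine-bearing phenyl on the triple-bonded carbon. Going by these compounds, it is equally open whether the same exchange would shift the number by a similar amount in compound 1, which carries cyclopentyl rather than cyclohexyl on the amide-type nitrogen.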